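The compounds below may be only part of what the source reports. "The series", "measured", "known", "first", "only" and "open" are said of these compounds alone.

In a functional assay on PC-3 cells (Homo sapiens) for antiproliferative activity, read by MTT assay, with a stated time of 24 h (on this read-out higher numbers stand for weaker inhibition and lower numbers for stronger inhibition), compound 1 (`CCn1c(C(=O)N[C@H](C)C(=O)OC)ccc1C(CC)(CC)c1ccc(OCS(=O)(=O)c2ccccc2)c(C)c1`) shows > 50000 nM, which is a limit of the assay. Compound 2 (`CCn1c(C(=O)NC2(C(=O)O)CC2)ccc1C(CC)(CC)c1ccc(OCS(=O)(=O)c2ccccc2)c(C)c1`) gives 26300 nM. Compound 3 (`CCn1c(C(=O)NCCC(=O)O)ccc1C(CC)(CC)c1ccc(OCS(=O)(=O)c2ccccc2)c(C)c1`) gives 14400 nM, and its nearest neighbour on the numbers is compound 2. Compound 4 (`CCn1c(C(=O)N[C@@H](CC(=O)O)C(=O)O)ccc1C(CC)(CC)c1ccc(OCS(=O)(=O)c2ccccc2)c(C)c1`) differs from compound 3 by carboxy in place of hydrogen on a saturated chain carbon bound to an amide-type nitrogen and a saturated chain carbon. Going by the values given here, no measured step makes this exact change. The closest guide is a 1.8-fold lower number from compound 2 to compound 3 (0.26 log units; within the scatter), which links two carboxy compounds, whereas an at least 3.4-fold lower number from compound 1 to compound 3 (0.54 log units; beyond the scatter) replaces the whole group on the amide-type nitrogen. No shift beyond the scatter is therefore expected, and the estimated step is a 1.5-fold higher number from compound 3 to compound 4 (0.18 log units; within the scatter). For compound 4 the estimate is 22000 nM, with an expected range of 8000 nM to 50000 nM.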

Compound 4, half-maximal inhibitory concentration: > 50000 nM
Compound 4: no number, only a limit; the forecaster's own chance of this, stated with the estimate: 25%; at least 2.2-fold (0.35 log units) between middle value and limit.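

In this assay, going by these compounds alone, carboxy in place of hydrogen on this saturated chain carbon, turning 2-carboxyethyl into 1,2-dicarboxyethyl, gives an at least 3.4-fold higher number from compound 3 to compound 4 (0.54 log units; beyond the scatter), the first step between carboxy compounds to pass the scatter. The comparison with the 1-carboxycyclopropyl group gives an at least 1.9-fold higher number from compound 2 to compound 4 (0.27 log units; that floor lies within the scatter). Compound 4 gives only a limit, as does compound 1, so the step between them cannot be read: the limit of > 50000 nM in this assay, at which 2 of the 4 values shown sit.

As far as these compounds go, it remains open whether this shift belongs to carboxy specifically or to any substituent on this carbon, such as a methyl group or an amine. From the compounds shown here alone, how far compound 4 lies past its limit also remains open.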